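From compound 2 to compound 4: losing the trifluoromethyl

This account rests on a few compounds, and the source may have more. Where it says the series, first, only, none or still open, it means among the compounds named here.

Going by the values given here, in an ADME assay on THP-1 cells (Homo sapiens) for cytotoxicity (a lower number here means that less compound is tolerated, a higher number that more compound is tolerated), compound 2 (`O=C(Nc1ccc(C(F)(F)F)cc1)c1c(NC(=O)C(F)(F)F)sc2c1CCCCC2`) gives 17200 nM as the only actual number among the three measured compounds. Compound 1 (`COc1ccc(NC(=O)c2ccsc2NC(=O)C(F)(F)F)cc1`) reports only a limit (> 50000 nM). Compound 3 (`COc1ccc(NC(=O)c2c(NC(=O)C(F)(F)F)sc(C)c2C)cc1`) reports only the same limit (> 50000 nM). Compound 4 (`O=C(Nc1ccccc1)c1c(NC(=O)C(F)(F)F)sc2c1CCCCC2`), not yet measured, differs from compound 2 by hydrogen in place of trifluoromethyl on an aromatic carbon. Among the compounds with values here, no measured pair isolates this change. Within the data shown here, the only hint is that compound 2 (17200 nM) alone of the three carries trifluoromethyl, though it also differs from the other two elsewhere. A modest rise is expected in this assay for the step (a 1.9-fold higher number from compound 2 to compound 4 (0.27 log units; within the scatter)). Compound 4 is estimated at 32000 nM with 15000 nM to 50000 nM as the expected range.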

Compound 4, half-maximal cytotoxic concentration: > 50000 nM
Compound 4 ended at the assay's limit; the forecaster's own chance of this, stated with the estimate: 35%; middle value at least 1.5-fold (0.19 log units) away from the limit.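

Here a single change is isolated for the first time: in this assay, going from 4-(trifluoromethyl)phenyl to phenyl gives an at least 2.9-fold higher number from compound 2 to compound 4 (0.46 log units; beyond the scatter). On this core, then, the trifluoromethyl at this position accounts for a step beyond the scatter, which compounds differing in several places could not show. The true size of the step stays unknown because compound 4 reaches only a limit: the limit of > 50000 nM in this assay, at which 3 of the 4 values shown sit.

Going by these compounds, whether an amine or a chlorine at this position would also stay at the limit remains open. So does whether trifluoromethyl has the same effect on the core of compound 1.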